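The compounds below may be only part of what the source reports. "The series", "measured", "known", "first", "only" and "open" are said of these compounds alone.

Measured so far:
- compound 1, `C=CC[C@H]1C[C@]2([C@@H](C)Cc3ccc(OC)cc3)OCOC2=CC1=O`: 20 nM
- compound 2, `C=CC[C@H]1C[C@]2([C@@H](C)Cc3ccc(OC)c(Cl)c3)OCOC2=CC1=O`: 240 nM

Among the measured compounds shown here, in a functional assay on M14 cells (Homo sapiens) for antiproliferative activity, with a stated time of 72 h (on this read-out lower numbers stand for stronger inhibition and higher numbers for weaker inhibition), compound 2 gives 240 nM, the higher of the two numbers recorded; its only neighbour is compound 1 with 20 nM. For the measured compounds named here, the single step available, a 12-fold higher number from compound 1 to compound 2 (1.08 log units; beyond the scatter), is large and lies beyond the scatter.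

Compound 3, `C=CC[C@H]1C[C@]2([C@@H](C)Cc3ccc(OC)c(O)c3)OCOC2=CC1=O`, differs from compound 2 by hydroxy in place of chloro on an aromatic carbon. Going by the values given here, the one measured step bears on it only indirectly: it shows that occupying this aromatic carbon with chloro is costly in this assay, but no compound carries hydroxy, or any other group, at the same carbon, so the data give no direct anchor for this change. The hydroxy is a single heavy atom, like the chloro it replaces, and the expectation is that removing the chloro recovers part of the loss seen between compound 1 and compound 2, without assuming a return to the number of compound 1.

For compound 3 the estimate in this assay is 100 nM, with a range of 25 nM to 400 nM, which corresponds to an expected step of a 2.4-fold lower number from compound 2 to compound 3 (0.38 log units; beyond the scatter).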

Compound 3, half-maximal inhibitory concentration: 8 nM
For compound 3 the middle estimate is 13-fold (1.10 log units) above the measured one; measured number below the stated range.
By their numbers in this assay, from the lowest: compound 3; then compound 1; then compound 2.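

In this assay, the aromatic carbon ortho to a methoxy group is not simply intolerant of substitution: with hydroxy in place of hydrogen, a 2.5-fold lower number from compound 1 to compound 3 (0.40 log units; beyond the scatter) is a modest improvement beyond the scatter, whereas chloro at the same carbon made the number worse. Exchanging chloro for hydroxy gives a 30-fold lower number from compound 2 to compound 3 (1.48 log units; beyond the scatter), a large step between two groups of 1 heavy atom each, so within these compounds the outcome at this carbon depends on which group sits there rather than on whether the carbon is substituted or on the heavy-atom count. No evidence is available on what underlies the difference between hydroxy and chloro here.

The compounds shown leave open whether the improvement is particular to hydroxy, or whether an amine, a fluoro or a second methoxy at this carbon would read on the same side of compound 1. Also open, going by these compounds, is whether hydroxy at this carbon keeps its effect when the methoxy group is exchanged for another group, such as an ethoxy or a hydroxy.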